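Adding a 4-chlorobenzoyl group to an inactive amine

The compounds below may be only part of what the source reports. "The series", "measured", "known", "first", "only" and "open" are said of these compounds alone.

Measured compounds:
- compound 1, `O=C(Nc1cccc(O)c1)C1c2ccccc2CCN1C(=O)c1ccc(Cl)cc1`: > 10000 nM in a functional assay on NUGC-3 cells (Homo sapiens) for inhibition, read by sulforhodamine B assay, with a stated time of 48 h; a higher number here means a weaker inhibitor of growth, a lower number a stronger inhibitor of growth
- compound 2, `O=C(Nc1ccccc1C(F)(F)F)C1NCCc2ccccc21`: > 10000 nM

Compound 2 stands at a limit rather than at a number. In this assay compound 2 gives > 10000 nM, which is the limit of the assay and not a measured concentration. The same holds for compound 1. In this assay compound 1 gives > 10000 nM, again a limit. Both values shown therefore sit at the same point, and this is the whole of the evidence: the limit of > 10000 nM in this assay, at which 2 of the 2 values shown sit.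

Compound 3, `O=C(Nc1ccccc1C(F)(F)F)C1c2ccccc2CCN1C(=O)c1ccc(Cl)cc1`, has not yet been measured in this assay. It differs from compound 2 in one place: (4-chlorophenyl)carbonyl in place of hydrogen on an amine nitrogen in a ring. Compound 1 carries this same (4-chlorophenyl)carbonyl on its amine nitrogen and still reaches only the limit, so the group alone has not shown any measurable growth inhibition here. Within the data shown here, no step between measured compounds exists, so the size and direction of the change from compound 2 to compound 3 cannot be read from data. The expectation is no step beyond the scatter, with compound 3 most likely remaining at the limit. Compound 3 is therefore estimated at 15000 nM, within 4000 nM to 60000 nM, a change of a step that the limit leaves unreadable from compound 2 to compound 3 from compound 2.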

Compound 3, concentration for 50% growth inhibition: > 10000 nM
Compound 3: only a limit was reported (the forecaster's own chance of this, stated with the estimate: 80%); the middle value lies beyond the limit too.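

In this assay compound 3 gives > 10000 nM, which is a limit and not a measured concentration. Among these compounds, no step to compound 3 from compound 1 or from compound 2 can therefore be read, as all the values sit at one point: the limit of > 10000 nM in this assay, at which 3 of the 3 values shown sit. The compounds shown leave open whether any change to the shared core gives measurable growth inhibition.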